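The compounds below may be only part of what the source reports. "The series", "measured", "known", "first", "only" and "open" are said of these compounds alone.

Measured compounds:
compound 1 `N#Cc1ccc(S(=O)(=O)[C@H]2CN(S(=O)(=O)c3ccc(Cl)cc3C#N)C[C@@]2(O)CO)cc1`, 2 nM
compound 2 `N#Cc1ccc(S(=O)(=O)[C@H]2CN(S(=O)(=O)c3ccc(C#N)cc3Cl)C[C@@]2(O)CO)cc1`, 3.2 nM
compound 3 `N#Cc1ccc(S(=O)(=O)N2C[C@H](S(=O)(=O)c3ccc(Cl)cc3)[C@](O)(CO)C2)c(C(F)(F)F)n1`, 20 nM

In an assay on cells for antagonist activity at transient receptor potential cation channel subfamily V member 4 (Homo sapiens), read by FLIPR and calcium flux, with a stated time of 10 min (a lower number here means a stronger inhibitor, a higher number a weaker inhibitor), compound 2 gives 3.2 nM, the second highest of the three numbers. Its nearest neighbour is compound 1; the two lie within the scatter of each other. Its furthest neighbour is compound 3, which gives 20 nM, a gap beyond the scatter.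

Among the compounds with values here, the only single-change step in the set is a 1.6-fold higher number from compound 1 to compound 2 (0.20 log units; within the scatter), which swaps the aryl on the sulfonyl attached to the ring nitrogen and stays within the scatter. Compound 4 `N#Cc1ccc(S(=O)(=O)N2C[C@H](S(=O)(=O)c3ccc(Cl)cn3)[C@](O)(CO)C2)c(Cl)c1` differs from compound 2 at the other sulfonyl: 5-chloropyridin-2-yl in place of 4-cyanophenyl on a sulfonyl sulfur. Within the data shown here, no measured step alters this group alone. Among the measured compounds shown here, compound 3 differs from compound 2 at both sulfonyl groups, so the gap between their values cannot be assigned to either change; it shows only that a compound without the 4-cyanophenyl on the carbon-bound sulfonyl sits at the weaker end of the series.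

For the measured compounds named here, with no direct precedent, a modest loss is expected for compound 4, the step being a 2.5-fold higher number from compound 2 to compound 4 (0.40 log units; beyond the scatter). Compound 4 is estimated at 8 nM in this assay, with a range from 3 nM to 25 nM.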

Compound 4, half-maximal inhibitory concentration: 5 nM
For compound 4 the middle estimate is 1.6-fold (0.20 log units) above the measured one; the measured number falls inside the stated range.
By their numbers in this assay, from the lowest: compounds 1, 2 and 4 (each within the scatter of the next, the first and the last beyond it); then compound 3.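

In this assay, within the data shown here, the exchange of 4-cyanophenyl for 5-chloropyridin-2-yl on the sulfonyl sulfur bound to a saturated ring carbon gives a 1.6-fold higher number from compound 2 to compound 4 (0.19 log units; within the scatter) and is the first single-change reading at this position, since the earlier step of a 1.6-fold higher number from compound 1 to compound 2 (0.20 log units; within the scatter) concerned only the aryl on the other sulfonyl. Within these two compounds, the 4-cyanophenyl and its nitrile are therefore not required at this position to keep a value within the scatter, and an aromatic ring with one hetero atom and a chlorine serves in its place. Nothing available explains why these two aryl groups read alike.

From the compounds shown here alone, whether this tolerance extends to other groups at this sulfonyl stays open, for example a 4-carboxyphenyl ring, a 4-aminophenyl ring or a saturated ring such as cyclohexyl. Also open, going by these compounds, is whether the exchange to 5-chloropyridin-2-yl reads the same when the other sulfonyl carries 4-chloro-2-cyanophenyl instead of 2-chloro-4-cyanophenyl, and how much each sulfonyl contributes to the value of compound 3 at 20 nM.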